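Methoxy to Methyl on a Second Spiro Core

The source may report more compounds than this note shows. Statements on the series, on what has been measured and on what is new or still open speak of the compounds shown alone.

Compound 2 `COc1ccc(-c2scc3c2CCOC32CCN(Cc3ccccc3)CC2)cc1` and compound 1 `Cc1ccc(-c2scc3c2CCOC32CCN(Cc3ccccc3)CC2)cc1` share one core and differ only at the para position of the phenyl ring. In an assay on membranes from brain for displacement of a labelled ligand from Sigma non-opioid intracellular receptor 1 (Cavia porcellus), read by scintillation counting, with a stated time of 120 min (on this read-out lower numbers stand for stronger inhibition and higher numbers for weaker inhibition), compound 2 gives 1.5 nM, while compound 1 gives 3.6 nM. The change, methyl in place of methoxy on an aromatic carbon, produced a 2.4-fold higher number from compound 2 to compound 1 (0.38 log units; beyond the scatter).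

Compound 3 `COc1ccc(-c2csc3c2CC(OC)OC32CCN(Cc3ccccc3)CC2)cc1` carries a second core, and how that core differs from the core of compound 2 is not broken down here. In this assay compound 3 gives 7.1 nM, the highest of the three numbers.

Compound 4 `COC1Cc2c(-c3ccc(C)cc3)csc2C2(CCN(Cc3ccccc3)CC2)O1` is compound 3 with the same change, methyl in place of methoxy on an aromatic carbon, at a place described in identical words. Because the earlier step of a 2.4-fold higher number from compound 2 to compound 1 (0.38 log units; beyond the scatter) pointed to a weaker number, a step of similar size is expected here: a 2.4-fold higher number from compound 3 to compound 4 (0.38 log units; beyond the scatter). Compound 4 is therefore estimated at 17 nM, most likely between 7 nM and 40 nM.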

Compound 4, inhibition constant: 2.7 nM
For compound 4 the middle estimate is 6.3-fold (0.80 log units) above the measured one, outside the stated range (below it).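

In this assay, putting methyl in place of methoxy on the second core gave a 2.6-fold lower number from compound 3 to compound 4 (0.42 log units; beyond the scatter), so the number moved in the opposite direction from the first core. The effect of this change therefore depends on the core that carries it, and a step read on one core gives no safe forecast for the other: the same change on two cores in this assay, a 2.4-fold higher number (0.38 log units; beyond the scatter) from compound 2 to compound 1 and a 2.6-fold lower number (0.42 log units; beyond the scatter) from compound 3 to compound 4, 6.3-fold (0.80 log units) apart, beyond the scatter of two such steps. This does not show which structural difference between the two cores matters or how the reversal arises, and two matched pairs are too few to set a rule for any further core.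

The compounds shown carry only methoxy or methyl on the six-membered aromatic ring, so it remains open how a hydroxyl group, a chlorine atom or a longer chain such as ethoxy would behave there on either core. From the compounds shown here alone, it also remains open whether the reversal would persist if the benzyl group on the ring nitrogen gave way to a simple methyl group.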